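Replacing an allyl ether with a 4-methylphenyl ether

The compounds below may be only part of what the source reports. "The series", "measured", "known", "first", "only" and "open" are said of these compounds alone.

Measured compounds:
compound 1, `CCCCc1c(Cl)cc(N/C=N/OCC)cc1Cl`, 5.6
compound 2, `C#CCc1c(Cl)cc(N/C=N/OCC=C)cc1Cl`, 3.7

Going by the values given here, the two compounds measured so far share the same core, and they were both measured in a physicochemical assay for lipophilicity, measured as octanol-water partition; a lower number here means a more polar compound, a higher number a more lipophilic compound. Compound 1 gives 5.6 in this assay. Compound 2 gives 3.7 in this assay, the lower of the two numbers, and compound 1 sits a good deal higher, well beyond the scatter of the method. Among the compounds with values here, no step between a matched pair is available here, since the two measured compounds differ in more than one place, so only the two values themselves can be compared.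

The next compound, compound 3, `C#CCc1c(Cl)cc(N/C=N/Oc2ccc(C)cc2)cc1Cl`, keeps the core and the side chain of compound 2 and changes only the group on the oxygen. 4-methylphenyl in place of allyl on an oxygen The group that enters is larger than the one that leaves and brings a second aromatic ring. The expected step of a number 1.70 log units higher from compound 2 to compound 3 (beyond the scatter) is therefore upward and is expected to lie clearly beyond the scatter. For compound 3 the estimate in this assay is 5.4, expected to fall between 4.8 and 6.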

Compound 3, partition coefficient: 4.8
Estimate against measurement, compound 3: 0.60 log units above; the range from low to high includes it.
By their numbers in this assay, from the lowest: compound 2; then compound 3; then compound 1.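

In this assay, putting 4-methylphenyl in place of allyl on an oxygen whose other neighbour is a double-bonded nitrogen gives a number 1.10 log units higher from compound 2 to compound 3 (beyond the scatter). Going by these compounds alone, this is the first reading of this position alone: the two earlier compounds differ in more than one place, whereas compound 2 and compound 3 share the core and the side chain, so the whole step belongs to the group on the oxygen and shows that the number in this assay responds to what sits there. The group that enters has 7 heavy atoms and one six-membered aromatic ring, the one that leaves has 3 heavy atoms and no ring, but nothing at hand explains the size of the step.

A single pair cannot separate the contribution of the aromatic ring from that of its methyl group, and an unsubstituted phenyl, a benzyl or a chain ending in an amine on the same oxygen would each test a different part of the change. As far as these compounds go, it also remains open whether the same exchange gives a similar step when the butyl chain of compound 1 stands in place of the side chain of compound 2.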